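Ortho-substituted benzamides: cytotoxicity outlook for the acetyl analogue

A few compounds are considered here, and "the series" means these few. Any claim that something is new, unique, unknown or untested is made for them only; others in the source may bear on it.

Measured so far:
compound 1 `Cc1ccccc1C(=O)Nc1nc(-c2ccccn2)cs1`: 6300 nM
compound 2 `COc1ccccc1C(=O)Nc1nc(-c2ccccn2)cs1`: 43500 nM
compound 3 `O=C(Nc1nc(-c2ccccn2)cs1)c1ccccc1O`: "not determined" (no result reported)

Among the measured compounds shown here, in an ADME assay on Vero cells (Chlorocebus sabaeus) for cytotoxicity, read by MTT assay, with a stated time of 72 h (on this read-out higher numbers stand for an effect only at larger amounts of compound and lower numbers for an effect already at smaller amounts), compound 1 gives 6300 nM and compound 2 gives 43500 nM; the one step, a 6.9-fold higher number from compound 1 to compound 2 (0.84 log units; beyond the scatter), shows that a change on the benzamide ring can move the read-out. For compound 3 the result in this assay is "not determined" (no result reported), so compound 3 stands nowhere on the numbers and the step to compound 4 `CC(=O)c1ccccc1C(=O)Nc1nc(-c2ccccn2)cs1` starts from an unknown. The change is acetyl in place of hydroxy on an aromatic carbon. For the measured compounds named here, no measured step touches a hydroxy or an acetyl; only the methoxy-for-methyl step sits on the same ring, and it was modest. The estimate for compound 4 in this assay is therefore placed between the two measured values, expected at 15000 nM, within 4000 nM to 60000 nM.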

Compound 4, half-maximal effective concentration: 86700 nM
The estimate for compound 4 lay 5.8-fold (0.76 log units) below the measured number; the measured number lies above the stated range.
By their numbers in this assay, from the lowest: compound 1; then compounds 2 and 4 (each within the scatter of the next).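

Acetyl in place of methyl gives a 14-fold higher number from compound 1 to compound 4 (1.14 log units; beyond the scatter) in this assay and moves the read-out on this aromatic carbon in the same direction as methoxy in place of methyl. Acetyl in place of methoxy gives a 2.0-fold higher number from compound 2 to compound 4 (0.30 log units; within the scatter) and leaves compound 2 and compound 4 inseparable, with compound 1 alone apart from both. Nothing at hand explains this result. The steps involving compound 3 cannot be read, so hydroxy remains unplaced. On these data alone, whether an amine or a carboxylic acid on this carbon would sit with compound 1 or with compound 2 and compound 4 remains open.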